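The source may report more compounds than this note shows. Statements on the series, on what has been measured and on what is new or still open speak of the compounds shown alone.

Compound 1 `CCC1(CCCCN2CCN(c3ccc(OC)cc3)CC2)C(=O)Nc2ccccc21` carries a 4-methoxyphenyl group on the ring nitrogen of its piperazine-like ring, joined to the shared core by a four-carbon chain. In a functional assay on the whole organism (strain NMRI) with Mus musculus as the target, with a stated time of 5 min (on this read-out higher numbers stand for an effect only at larger amounts of compound and lower numbers for an effect already at smaller amounts), compound 1 has "not determined" (no result reported), so there is no number that places it among the other entries. For the measured compounds named here, the only measured relative is compound 2 `CCC1(CCCCCN2CCN(c3cccc(Cl)c3)CC2)C(=O)Nc2ccccc21`, which differs from compound 1 in its chain and its aromatic group together. In this assay compound 2 reaches only a limit, > 10 mg/kg, meaning no effect was seen up to the largest amount tested. This is the one result shown here, as the limit of > 10 mg/kg in this assay, at which 1 of the 2 values shown sits, records.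

Compound 3 `CCC1(CCCCN2CCN(c3cccc(Cl)c3)CC2)C(=O)Nc2ccccc21` has not yet been measured. It is reached from compound 1 by 3-chlorophenyl in place of 4-methoxyphenyl on an amine nitrogen in a ring. Going by the values given here, no measured step matches this change, so its size and direction cannot be read from the data. The closest guide is compound 2, whose result sits at the limit.

Compound 3 is therefore expected to give roughly 15 mg/kg in this assay, with a range from 3 mg/kg to 60 mg/kg, and it may well return only a limit again.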

Compound 3, minimum effective dose: > 10 mg/kg
Compound 3 ended at the assay's limit (the forecaster's own chance of this, stated with the estimate: 65%); the middle value does not contradict the limit.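

No step can be read in this assay among compound 1, compound 2 and compound 3: compound 1 has no reported result, and the other two end at a limit of the assay. The compounds shown leave open at what dose compound 2 or compound 3 would act, and whether the chain or the aromatic group alters the result in this assay.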